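Methoxy to trifluoromethyl, repeated at a second place

The source may hold more compounds than are shown below. What is called first, only, known or untested is meant among the compounds shown, and "the series" means these compounds.

Measured so far:
compound 1, `COc1ccccc1Cn1cnnc1-c1cccc(Cl)c1Cl`, 191 nM
compound 2, `FC(F)(F)c1ccccc1Cn1cnnc1-c1cccc(Cl)c1Cl`, 132 nM
compound 3, `COc1cccc(Cn2cnnc2-c2cccc(Cl)c2Cl)c1`, 214 nM

All three were run in a functional assay for antagonist activity at P2X purinoceptor 7 (Homo sapiens); a lower number here means a stronger inhibitor, a higher number a weaker inhibitor. Compound 1 gives 191 nM in this assay, and compound 2 gives 132 nM. The two differ in one place only, (trifluoromethyl in place of methoxy on an aromatic carbon), and that change made a 1.4-fold lower number from compound 1 to compound 2 (0.16 log units; within the scatter). Compound 3 gives 214 nM in this assay. Compound 1 and compound 3 contain the same atoms joined differently; the difference between the two cores is not broken down here. The values of compound 1 and compound 3 lie within the scatter of each other, and so do those of compound 3 and compound 2, so no order among the three is claimed.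

Compound 4, `FC(F)(F)c1cccc(Cn2cnnc2-c2cccc(Cl)c2Cl)c1`, is not yet measured. It differs from compound 3 by trifluoromethyl in place of methoxy on an aromatic carbon. Among the measured compounds shown here, this is the same kind of change as the one from compound 1 to compound 2, but not the same: in compound 2 the trifluoromethyl sits ortho to a large group, in compound 4 it sits meta to a large group. For the measured compounds named here, with only one earlier instance, the step is expected to be small, a 1.4-fold lower number from compound 3 to compound 4 (0.15 log units; within the scatter), resting on the step of a 1.4-fold lower number from compound 1 to compound 2 (0.16 log units; within the scatter) seen in the first instance. For compound 4 in this assay the estimate is 150 nM, expected to fall between 70 nM and 320 nM.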

Compound 4, half-maximal inhibitory concentration: 1290 nM
Estimate against measurement, compound 4: 8.6-fold (0.93 log units) below; the measured number lies above the stated range.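

Carried to a second place in this assay, trifluoromethyl in place of methoxy on an aromatic carbon gave a 6.0-fold higher number from compound 3 to compound 4 (0.78 log units; beyond the scatter). The result of this change therefore does not transfer unchanged from one core to the other in this series, and the step seen first is a poor guide to the second: the same change on two cores in this assay, a 1.4-fold lower number (0.16 log units; within the scatter) from compound 1 to compound 2 and a 6.0-fold higher number (0.78 log units; beyond the scatter) from compound 3 to compound 4, 8.7-fold (0.94 log units) apart, beyond the scatter of two such steps

Among the compounds shown here, this does not show what produces the gap, since only two pairs are at hand, no property of either group has been measured, and the pairs alone give no general rule for other places on the ring or for other cores.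

Open, as far as these compounds go, is whether the higher number of compound 4 is particular to trifluoromethyl or is shared by other groups meta to a large group, which a chlorine atom, a nitrile or an amine at that place would begin to separate. Also open, from the compounds shown here alone, is whether any group at that place matches methoxy or improves on it, and whether a hydroxyl or a longer ether chain would follow methoxy or trifluoromethyl there.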